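This account rests on a few compounds, and the source may have more. Where it says the series, first, only, none or still open, it means among the compounds named here.

Compound 3 `CCCCCOc1cccc2ccc(N)nc12` stands lowest among the numbers from an assay on cells with melanin-concentrating hormone receptor 1 (Homo sapiens) as the target, read by radioligand binding; on this read-out lower numbers stand for stronger inhibition and higher numbers for weaker inhibition: in that assay compound 3 gives 580 nM. Its nearest neighbour is compound 2 `CC1CC1COc1cccc2ccc(N)nc12`, which in this assay gives 1640 nM; the step between them was a 2.8-fold lower number from compound 2 to compound 3 (0.45 log units; beyond the scatter). Compound 1 `CCOCCOc1cccc2ccc(N)nc12` reaches only the limit of this assay, > 2000 nM. Starting from that limit, the step was an at least 3.4-fold lower number from compound 1 to compound 3 (0.53 log units; beyond the scatter). Compound 4 `CC(C)Oc1cccc2ccc(N)nc12` has not yet been measured; it differs from compound 3 by isopropyl in place of pentyl on an oxygen on an aromatic ring. Because a 2.8-fold lower number from compound 2 to compound 3 (0.45 log units; beyond the scatter) and an at least 3.4-fold lower number from compound 1 to compound 3 (0.53 log units; beyond the scatter) both ended in compound 3 with a lower number after the group attached to the aromatic oxygen was changed, the shorter isopropyl group in compound 4 is expected to move the number back up by a modest amount, a 2.6-fold higher number from compound 3 to compound 4 (0.41 log units; beyond the scatter), in this assay. Compound 4 is therefore estimated at 1500 nM, with a range from 600 nM to 4000 nM expected to hold most repeat measurements.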

Compound 4, half-maximal inhibitory concentration: 437 nM
For compound 4 the middle estimate is 3.4-fold (0.54 log units) above the measured one, outside the stated range (below it).
By their numbers in this assay, from the lowest: compounds 4 and 3 (each within the scatter of the next); then compound 2. At a limit, above all of these: compound 1.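

Swapping pentyl for the shorter isopropyl on the oxygen on the aromatic ring leaves the reading in this assay within the scatter (a 1.3-fold lower number from compound 3 to compound 4 (0.12 log units; within the scatter)), so among these compounds a pentyl chain is not needed to keep the number at this level. Isopropyl also stands clearly apart from the (2-methylcyclopropyl)methyl group (a 3.8-fold lower number from compound 2 to compound 4 (0.57 log units; beyond the scatter)), which shows that the number at this position does not simply follow the length of the group. The comparison with 2-ethoxyethyl (an at least 4.5-fold lower number from compound 1 to compound 4 (0.66 log units; beyond the scatter)) gives only a floor, and compound 1 gives a limit, not a number: the limit of > 2000 nM in this assay, at which 1 of the 4 values shown sits.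

From the compounds shown here alone, how a methyl group, a longer chain such as hexyl, or a chain ending in an amine would read at this oxygen remains open. Also open, going by these compounds, is whether isopropyl and pentyl would stay level if the shared core were changed elsewhere.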